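Methoxy in Place of Nitro on the Sulfonyl Ring

The source may report more compounds than this note shows. Statements on the series, on what has been measured and on what is new or still open speak of the compounds shown alone.

Compound 2 `COc1cc2c(cc1OC)C(/C(C)=N/NC(N)=S)N(S(=O)(=O)c1ccc([N+](=O)[O-])cc1)CC2` shares its core with compound 1 `COc1cc2c(cc1OC)C(/C(C)=N/NC(N)=S)N(S(=O)(=O)c1ccc(C)cc1)CC2` and carries nitro in place of methyl on an aromatic carbon. In a functional assay on HuCC-A1 cells (Homo sapiens) for cytotoxicity, read by crystal violet staining, with a stated time of 3 days (on this read-out higher numbers stand for weaker inhibition and lower numbers for stronger inhibition), compound 1 gives only a limit, > 50 ug/mL. In this assay compound 2 likewise gives only a limit, > 50 ug/mL. The step that the two limits leave unreadable from compound 1 to compound 2 cannot be read in size or direction, since both values sit at the limit of > 50 ug/mL in this assay, at which 2 of the 2 values shown sit. Compound 3 `COc1ccc(S(=O)(=O)N2CCc3cc(OC)c(OC)cc3C2/C(C)=N/NC(N)=S)cc1` differs from compound 2 by methoxy in place of nitro on an aromatic carbon. Among the measured compounds shown here, only that one unreadable step bears on this change, so no size or direction can be taken from it. Compound 3 is therefore expected to behave much as the two measured compounds do, with an expected step that the limit leaves unreadable from compound 2 to compound 3 in this assay. For compound 3 the estimate in this assay is 70 ug/mL, in the range 30 ug/mL to 200 ug/mL, most likely again reported only as a limit.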

Compound 3, half-maximal inhibitory concentration: 31 ug/mL
The estimate for compound 3 lay 2.3-fold (0.35 log units) above the measured number, and the stated range covers the measured number.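

Among the three compounds, only compound 3 gives a true number in this assay, so the group at this position on the sulfonyl ring can decide whether a number is obtained at all, and 4-methoxyphenyl is the only group shown that yields one. Methoxy in place of nitro gives an at least 1.6-fold lower number from compound 2 to compound 3 (0.20 log units; that floor lies within the scatter), and methoxy in place of methyl gives an at least 1.6-fold lower number from compound 1 to compound 3 (0.20 log units; that floor lies within the scatter). Each step is only a floor, and its true size stays unknown, because its other end is a limit and not a number: the limit of > 50 ug/mL in this assay, at which 2 of the 3 values shown sit.

The step between the methyl and nitro compounds still cannot be read, so no order among the three groups can be drawn. On these data alone, whether an amine, a carboxylic acid or a chlorine atom at this position would give a number or stay at the limit remains open.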